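The source may report more compounds than this note shows. Statements on the series, on what has been measured and on what is new or still open speak of the compounds shown alone.

Measured so far in a physicochemical assay, read by spectrophotometry, with a stated time of 30 min; a higher number here means a weaker inhibitor, a lower number a stronger inhibitor:
compound 1, `O=[N+]([O-])c1cccc(Cn2cc(COc3ccccc3)nn2)c1`, gives 25.3 ug/mL
compound 2, `Cc1ccc(OCc2cn(Cc3cccc([N+](=O)[O-])c3)nn2)cc1`, gives 12.1 ug/mL
compound 3, `O=[N+]([O-])c1ccc(Cn2cc(COc3ccc(Cl)cc3)nn2)cc1`, gives 24.2 ug/mL

Compound 2 differs from compound 1 by methyl in place of hydrogen on an aromatic carbon. That single change produced a 2.1-fold lower number from compound 1 to compound 2 (0.32 log units; beyond the scatter). Compound 3 rests on a different core than compound 1; how the two cores differ is not broken down here, and the two numbers sit within the scatter of each other.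

Compound 4, `Cc1cc(OCc2cn(Cc3ccc([N+](=O)[O-])cc3)nn2)ccc1Cl`, has not yet been measured. It differs from compound 3 by methyl in place of hydrogen on an aromatic carbon. In compound 2 the methyl sits para to a large group, whereas in compound 4 it sits ortho to a chloro group and meta to a large group, so this is the same kind of change as before, not the same one. Among the compounds with values here, the earlier step is the only guide, and with a different core and different surroundings a step in the same direction but somewhat smaller is expected, a 1.6-fold lower number from compound 3 to compound 4 (0.21 log units; within the scatter). That expectation rests on compound 3, which gives 24.2 ug/mL, and on the earlier step. Compound 4 is expected to give about 15 ug/mL, likely between 8 ug/mL and 30 ug/mL.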

Compound 4, half-maximal inhibitory concentration: 13.4 ug/mL
Beside the measured number, compound 4's estimate is 1.1-fold (0.05 log units) above it; the range from low to high includes it.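

In this assay, the step from 4-chlorophenyl to 4-chloro-3-methylphenyl gave a 1.8-fold lower number from compound 3 to compound 4 (0.26 log units; within the scatter), while the same kind of change on the core of compound 1 gave a 2.1-fold lower number from compound 1 to compound 2 (0.32 log units; beyond the scatter), so both steps printed a lower number. Within the data shown here, only the step on the core of compound 1 lies beyond the scatter, and with just two examples, on two cores and in different surroundings, the new step is compatible with the methyl change carrying over but does not show that it does. Nothing measured here explains the size of either step.

The compounds shown leave open whether another group in the place of this methyl, ortho to a chloro group, such as an ethyl group, a methoxy group or an amine, would give a step beyond the scatter. They also leave open how the series would read with the nitro group replaced, for instance by a nitrile or a carboxylic acid.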